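The source may hold more compounds than are shown below. What is called first, only, known or untested is meant among the compounds shown, and "the series" means these compounds.

Working notes on the series, carried forward to compound 4.

Compound 1 `CC#C[C@@H](Cc1nnn[nH]1)c1ccc(OCc2ccc3sc(F)c(-c4ccccc4C)c3c2)cc1` is the reference point. Going by the values given here, in a functional assay on cells for agonist activity at Free fatty acid receptor 1 (Homo sapiens), read by FLIPR and calcium flux (a higher number here means that more compound is needed for the effect, a lower number that less compound is needed), compound 1 gives 15 nM, the lowest number among the three compounds measured so far. Compound 3 `CC#C[C@@H](Cc1nnn[nH]1)c1ccc(OCc2ccc3sc(F)c(-c4ccc(OCCOC)cc4C)c3c2)cc1` gives 18 nM in this assay, and the step of a 1.2-fold higher number from compound 1 to compound 3 (0.08 log units; within the scatter) shows that putting a 2-methoxyethoxy group on the pendant ring leaves the number where it was. Among the compounds with values here, compound 2 `CC#C[C@@H](Cc1nnn[nH]1)c1ccc(OCc2cc(Cl)c3scc(-c4ccccc4C)c3c2)cc1` gives 63 nM; it carries chloro on a different ring carbon and lacks the fluoro of compound 1, so it differs in more than one place and no single step to compound 1 can be drawn from it. Its value simply sits furthest from that of compound 1, beyond the scatter.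

Compound 4 `CC#C[C@@H](Cc1nnn[nH]1)c1ccc(OCc2ccc3sc(Cl)c(-c4ccccc4C)c3c2)cc1` is the next case: chloro in place of fluoro on an aromatic carbon. Within the data shown here, none of the measured steps touches this position, so there is no direct precedent. Among the measured compounds shown here, the only one-place step in hand, from compound 1 to compound 3, was within the scatter and concerns another site. With nothing pointing to a shift in either direction, the number for compound 4 in this assay is expected to stay close to that of compound 1, the expected step being a 1.3-fold higher number from compound 1 to compound 4 (0.12 log units; within the scatter). The estimate for compound 4 is 20 nM, with a range from 7 nM to 55 nM.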

Compound 4, half-maximal effective concentration: 20 nM
Estimate against measurement, compound 4: no gap at the digits printed, within the range that was stated.
By their numbers in this assay, from the lowest: compounds 1, 3 and 4 (each within the scatter of the next); then compound 2.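

Going by these compounds alone, the step of a 1.3-fold higher number from compound 1 to compound 4 (0.12 log units; within the scatter) in this assay is the first one-place reading at this position, on an aromatic carbon of the five-membered aromatic ring with 1 sulfur, next to the ring sulfur and next to the ring atom that bears a 2-methylphenyl group. It shows that, in the core of compound 1, chloro can stand in place of fluoro at this position without a shift beyond the scatter, something the earlier step could not show, as it concerned the 2-methoxyethoxy group at another site. Nothing in hand bears on the reason for this result.

As far as these compounds go, the comparison covers only these two halogens, so it remains open whether the number would hold with a nitrile, an amine or a longer chain such as propyl at this position. Also open, from the compounds shown here alone, is whether chloro at this position and the 2-methoxyethoxy group of compound 3 would leave the number in the same place if they stood together on the core of compound 1.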